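Sulfonyl in Place of Amide on the Shared Core

A few compounds are considered here, and "the series" means these few. Any claim that something is new, unique, unknown or untested is made for them only; others in the source may bear on it.

Compound 2 `COc1ccc(C(=O)N(C)c2ccc3[nH]c(-c4n[nH]c5ccccc45)cc3n2)cc1` carries a (4-methoxyphenyl)carbonyl on a nitrogen on an aromatic ring of the shared core. In a functional assay on HCT-116 cells (Homo sapiens) for antiproliferative activity, read by MTT assay, with a stated time of 72 h (a higher number here means a weaker inhibitor, a lower number a stronger inhibitor), compound 2 gives 29500 nM, the highest of the two numbers in hand. Its nearest neighbour is compound 1 `CC(=O)N(C)c1ccc2[nH]c(-c3n[nH]c4ccccc34)cc2n1`, which in this assay gives 14800 nM; the step of a 2.0-fold higher number from compound 1 to compound 2 (0.30 log units; within the scatter) lies within the scatter, so the two values do not separate. Compound 3 `CN(c1ccc2[nH]c(-c3n[nH]c4ccccc34)cc2n1)S(=O)(=O)c1ccccc1` is not yet measured. It differs from compound 2 by phenylsulfonyl in place of (4-methoxyphenyl)carbonyl on a nitrogen on an aromatic ring. Within the data shown here, the only measured step that touches this nitrogen is a 2.0-fold higher number from compound 1 to compound 2 (0.30 log units; within the scatter), which did not move the number beyond the scatter; no measured pair compares a carbonyl with a sulfonyl. On that basis the expectation is a change of no more than the scatter, a 1.2-fold lower number from compound 2 to compound 3 (0.07 log units; within the scatter). For compound 3 in this assay the estimate is 25000 nM, with a range from 8000 nM to 80000 nM.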

Compound 3, half-maximal inhibitory concentration: 6740 nM
Compound 3: middle estimate off by 3.7-fold (0.57 log units), on the high side; measured number below the stated range.
By their numbers in this assay, from the lowest: compound 3; then compounds 1 and 2 (each within the scatter of the next).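

The nitrogen on an aromatic ring had not separated its two carbonyl groups, but phenylsulfonyl stands apart from both: in this assay replacing (4-methoxyphenyl)carbonyl gives a 4.4-fold lower number from compound 2 to compound 3 (0.64 log units; beyond the scatter) and replacing acetyl gives a 2.2-fold lower number from compound 1 to compound 3 (0.34 log units; beyond the scatter) as well. The number at this position therefore does respond to the group on the nitrogen, and compound 3 has the lowest number of the three shown, with both of its steps beyond the scatter. No evidence is available on why the sulfonyl group differs from the carbonyl groups here.

Compound 3 also lacks the methoxy group of compound 2, so the compounds shown do not tell the sulfonyl link apart from that loss. On these data alone, whether a methylsulfonyl or a 4-methoxyphenylsulfonyl group on this nitrogen would keep the lower number remains open, as does the effect of a simple benzoyl group.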